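The compounds below may be only part of what the source reports. "The series", "measured", "known", "first", "only" and "open" are said of these compounds alone.

- compound 1 `NC1=NC2(CCSCC2)N(OCCCOc2cccc(Cl)c2)C(N)=N1`: 1 nM
- compound 2 `NC1=NC2(CCSCC2)N(OCCCOc2cccc(Cl)c2Cl)C(N)=N1`: 1 nM

In a functional assay on HCT-116 cells (Homo sapiens) for antiproliferative activity, read by MTT assay, with a stated time of 72 h (a higher number here means a weaker inhibitor, a lower number a stronger inhibitor), compound 1 sits level with compound 2, at 1 nM. Compound 3 `NC1=NC2(CCSCC2)N(OCCCOc2cc(Cl)c(Cl)cc2Cl)C(N)=N1` has 2,4,5-trichlorophenyl in place of 2,3-dichlorophenyl on an oxygen on a saturated carbon. Within the data shown here, only one measured step bears on this, chloro in place of hydrogen on an aromatic carbon: no change at the digits printed from compound 1 to compound 2 (within the scatter). That single step gives no reason to expect a change beyond the scatter in this assay, but this chlorine arrangement is untested, so the range extends further towards weaker values. The expected step is a 1.5-fold higher number from compound 2 to compound 3 (0.18 log units; within the scatter). For compound 3 the estimated value is 1.5 nM, with an expected range of 0.5 nM to 6 nM.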

Compound 3, half-maximal inhibitory concentration: 1 nM
Beside the measured number, compound 3's estimate is 1.5-fold (0.18 log units) above it; the range from low to high includes it.
By their numbers in this assay, from the lowest: compounds 1, 2 and 3 (each within the scatter of the next).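

In this assay, the step to 2,4,5-trichlorophenyl gives no change at the digits printed from compound 2 to compound 3 (within the scatter), and the wider jump from 3-chlorophenyl gives no change at the digits printed from compound 1 to compound 3 (within the scatter), so a third chlorine and a new chlorine arrangement both leave the reading unmoved at this position. Together with the earlier step, this means that three chlorine patterns on the aromatic ring now give the same printed reading. No measured evidence here explains this flat result. Still open, as far as these compounds go, is whether groups other than chlorine on the ring, such as methoxy or nitrile, would behave alike. A longer chain, or an amine in place of the aromatic ring, is equally untested among these compounds.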